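Cutting (hex-5-yn-1-yl)oxy back to methoxy

The source may report more compounds than this note shows. Statements on the series, on what has been measured and on what is new or still open speak of the compounds shown alone.

In a functional assay on LoVo cells (Homo sapiens) for inhibition, read by colorimetric assay and MTT assay, with a stated time of 72 h (on this read-out lower numbers stand for stronger inhibition and higher numbers for weaker inhibition), compound 1 (`CCCCOc1ncc(-c2ccccc2OC)n1C`) gives (39000 nM) and compound 2 (`C#CCCCCOc1ncc(-c2ccccc2OC)n1C`) gives (11000 nM), the lower of the two numbers. Compound 3 (`COc1ccccc1-c1cnc(OC)n1C`) differs from compound 2 by hydrogen in place of pent-4-yn-1-yl on a saturated chain carbon bound to an oxygen on an aromatic ring. Among the compounds with values here, the one measured step bearing on this is modest but beyond the scatter (a 3.5-fold lower number from compound 1 to compound 2 (0.55 log units; beyond the scatter)), and it runs towards the longer ethynyl-bearing chain. Removing that chain is therefore expected to give a step of similar size towards weaker inhibition (a 4.1-fold higher number from compound 2 to compound 3 (0.61 log units; beyond the scatter)). For compound 3 the estimated value is 45000 nM (expected range 18000 nM to 120000 nM).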

Compound 3, half-maximal inhibitory concentration: 73000 nM
Estimate against measurement, compound 3: 1.6-fold (0.21 log units) below, within the range that was stated.
By their numbers in this assay, from the lowest: compound 2; then compounds 1 and 3 (each within the scatter of the next).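

Across the full cut from (hex-5-yn-1-yl)oxy to methoxy, the number rises beyond the scatter (a 6.6-fold higher number from compound 2 to compound 3 (0.82 log units; beyond the scatter)), a larger step than the one that adds ethynyl to the chain. Cutting propyl back to hydrogen at the same place, by contrast, stays within the scatter (a 1.9-fold higher number from compound 1 to compound 3 (0.27 log units; within the scatter)), so among these compounds only the hex-5-yn-1-yl chain of compound 2 stands apart from the methoxy of compound 3. Nothing available explains either step.

Still open, on these data alone, is whether a plain hexyl chain would read like hex-5-yn-1-yl or like the shorter groups. As far as these compounds go, how a longer alkyne chain, or an amine or carboxylic acid in place of the ethynyl, would read also remains open.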